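Compound 2 to compound 4: chloro on a phenyl

The compounds below may be only part of what the source reports. "The series", "measured", "known", "first", "only" and "open" are said of these compounds alone.

In a toxicity assay on Huh-7.5 cells (Homo sapiens) for cytotoxicity, read by MTT assay, with a stated time of 96 h (a higher number here means that more compound is tolerated, a lower number that less compound is tolerated), compound 1 `CN(C)CCN(C)c1ccc(C#N)c(CN2CCN(C(c3ccccc3)c3ccccc3)CC2)c1` gives > 20000 nM, which is a limit. Compound 2 `N#Cc1ccc(NCCCn2ccnc2)cc1CN1CCN(C(c2ccccc2)c2ccccc2)CC1` gives > 20000 nM, also a limit, so its position is known only as a limit. Going by the values given here, the one measured step, a step that the two limits leave unreadable from compound 1 to compound 2, offers no size to carry forward. The record is dominated by the limit of > 20000 nM in this assay, at which 2 of the 3 values shown sit. Compound 3 `CN1CCCN(c2ccc(C#N)c(CN3CCN(C(c4ccc(F)cc4)c4ccc(F)cc4)CC3)c2)CC1`, which has halogen on its aryl rings and a different amine chain, gives 6240 nM.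

Compound 4 `N#Cc1ccc(NCCCn2ccnc2)cc1CN1CCN(C(c2ccccc2)c2ccc(Cl)cc2)CC1` differs from compound 2 by chloro in place of hydrogen on an aromatic carbon, phenyl to 4-chlorophenyl. The value of compound 3 at 6240 nM allows a modest fall. For compound 4 a further limit remains possible. The estimated change is an at least 1.3-fold lower number from compound 2 to compound 4 (0.12 log units; that floor lies within the scatter), toward less compound tolerated in this assay. For compound 4 the expected value is 15000 nM, with an estimated range of 6000 nM to 30000 nM.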

Compound 4, half-maximal cytotoxic concentration: 5380 nM
For compound 4 the middle estimate is 2.8-fold (0.45 log units) above the measured one, outside the stated range (below it).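

In this assay, going by these compounds alone, the phenyl to 4-chlorophenyl change gives an at least 3.7-fold lower number from compound 2 to compound 4 (0.57 log units; beyond the scatter) with the (3-(1H-imidazol-1-yl)propyl)amino group unchanged, the first readable step in this set. On these data alone, the true size stays open, since compound 2 carries only a limit: the limit of > 20000 nM in this assay, at which 2 of the 4 values shown sit. Compound 3 differs from these compounds in more than one place and so adds nothing on this change.

As far as these compounds go, whether chloro acts alike with the (2-(dimethylamino)ethyl)(methyl)amino group of compound 1 remains open. So does the outcome with bromo or methoxy in place of chloro.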